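Swapping an amide side chain for an anisylidene imine

This account rests on a few compounds, and the source may have more. Where it says the series, first, only, none or still open, it means among the compounds named here.

Measured so far:
compound 1 `N#CC1=C(NCC(=O)N2CCOCC2)N(c2ccccc2)C(=O)N2CCCCC(N3CCCC3)C12`: 69.8%
compound 2 `N#CC1=C(/N=C/c2ccccc2)N(c2ccccc2)C(=O)N2CCCCC(N3CCCC3)C12`: 75.9%
compound 3 `CCOC(=O)C(=O)NC1=C(C#N)C2C(N3CCCC3)CCCCN2C(=O)N1c1ccccc1`: 83.6%

Three compounds sharing one core were tested in a functional assay on the whole organism (strain albino) for inhibition, with Rattus norvegicus as the target, read by paw edema, with stated times of 1 h and 2 h, at a dose of 20 mmol/kg by the intraperitoneal route; on this read-out lower numbers stand for less inhibition and higher numbers for more inhibition at the one dose given (going by the name of the read-out). Compound 1 gives the lowest of the three numbers; compound 2 is nearest, its step of a number 6.1 percentage points higher from compound 1 to compound 2 (within the scatter), while compound 3 is furthest, its step of a number 13.8 percentage points higher from compound 1 to compound 3 (beyond the scatter). Between the other two, a number 7.7 percentage points higher from compound 2 to compound 3 (within the scatter).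

Compound 4 `COc1ccc(/C=N/C2=C(C#N)C3C(N4CCCC4)CCCCN3C(=O)N2c2ccccc2)cc1` is not yet measured. It differs from compound 1 in one place: a group of 10 heavy atoms (8 carbon, 1 nitrogen, 1 oxygen; one six-membered aromatic ring of carbon only) in place of a group of 10 heavy atoms (6 carbon, 2 nitrogen, 2 oxygen; one six-membered non-aromatic ring with 2 hetero atoms), on a double-bonded ring carbon.

Among the measured compounds shown here, only one measured step bears on this change directly. Going from compound 1 to compound 2 replaces the same amide side chain with a benzylidene-type imine of the same kind that enters in compound 4, the imine of compound 4 carrying an added methoxy group on its aromatic ring; that step, a number 6.1 percentage points higher from compound 1 to compound 2 (within the scatter), stayed within the scatter. For the measured compounds named here, no measured pair shows what a methoxy group on that ring does, so the outcome is expected to resemble compound 2 rather than move beyond it.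

For compound 4 in this assay the expected step is a number 4.2 percentage points higher from compound 1 to compound 4 (within the scatter). Compound 4 is therefore estimated at 74%, with a range from 62% to 86%.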

Compound 4, a percentage reported as inhibition, in the whole organism at one dose (the size of the read-out at that dose, not a potency): 71.6%
For compound 4 the middle estimate is 2.4 percentage points above the measured one, within the range that was stated.
By their numbers in this assay, from the lowest: compounds 1, 4, 2 and 3 (each within the scatter of the next, the first and the last beyond it).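

In this assay, the methoxy group on the aromatic ring of the imine can now be read directly, and the step it brings (a number 4.3 percentage points lower from compound 2 to compound 4 (within the scatter)) shows that this addition does not move the number outside the usual spread of repeat measurements. The methoxy-bearing imine also cannot be told apart from the (((morpholin-4-yl)carbonyl)methyl)amino side chain at this double-bonded ring carbon (a number 1.8 percentage points higher from compound 1 to compound 4 (within the scatter)), so two quite different groups give similar numbers here. The side chain of compound 3, which carries the (ethoxycarbonyl)carbonyl group, now has a gap beyond the scatter to this imine (a number 12 percentage points lower from compound 3 to compound 4 (beyond the scatter)), whereas its gap to the imine without methoxy stayed within the scatter; no measurement at hand explains these numbers.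

From the compounds shown here alone, with one substituent at one place on the ring, it remains open whether a chlorine atom or a hydroxyl group there would behave like methoxy. Going by these compounds, it is equally open whether a carboxylic acid in place of the ethyl ester of compound 3 would hold that compound's number, and a single dose says nothing about potency.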